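Anilino Replacement on a Kinase Inhibitor Scaffold

The source may hold more compounds than are shown below. What is called first, only, known or untested is meant among the compounds shown, and "the series" means these compounds.

Measured so far:
- compound 1, `OCCNc1nccc(-c2c[nH]c3ccccc23)n1`: 11000 nM
- compound 2, `COCCCNc1nccc(-c2c(C)[nH]c3ccccc23)n1`: 1500 nM

In an assay on isolated protein for inhibition of interferon-induced, double-stranded RNA-activated protein kinase (Homo sapiens), read by luminescence, with a stated time of 10 min (a higher number here means a weaker inhibitor, a lower number a stronger inhibitor), compound 2 gives 1500 nM. Of the two measured compounds, compound 2 has the lower number, and the gap to compound 1, which gives 11000 nM, is larger than the usual scatter of repeated measurements. The two compounds differ in more than one place, so only their two values can be compared; no single change can be credited with the gap.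

Compound 3, `Cc1[nH]c2ccccc2c1-c1ccnc(Nc2cccc(Cl)c2)n1`, has not yet been measured in this assay. It keeps the core of compound 2 and changes one group: 3-chlorophenyl in place of 3-methoxypropyl on a nitrogen on an aromatic ring. In words, a flexible chain that ends in an ether is exchanged for a flat aromatic ring bearing a chlorine.

Among the measured compounds shown here, no measured pair shows this exact exchange, so the size of the step cannot be taken from the numbers already in hand. The expectation for compound 3 is a clear gain in potency, a step of a 5.0-fold lower number from compound 2 to compound 3 (0.70 log units; beyond the scatter) downward in this assay, with an estimated value of 300 nM and a range from 80 nM to 1500 nM.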

Compound 3, half-maximal inhibitory concentration: 300 nM
Compound 3: the middle estimate sits on the measured number at the digits printed; the range from low to high includes it.
By their numbers in this assay, from the lowest: compound 3; then compound 2; then compound 1.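

In this assay, replacing 3-methoxypropyl with 3-chlorophenyl on a nitrogen on an aromatic ring gives a 5.0-fold lower number from compound 2 to compound 3 (0.70 log units; beyond the scatter), and this is the first change shown that can be read on its own. It shows that this position accepts a six-membered aromatic ring of carbon only in place of a flexible chain, and that the oxygen of the chain is not required to reach the lower number, since the entering group has 0 hydrogen-bond acceptors. Nothing shown here explains why the number falls.

From the compounds shown here alone, the step swaps a chain for a ring and adds a chlorine in one move, so the share of each remains open: a plain phenyl group would separate the two, while a fluorine, a methoxy or a nitrile in place of the chlorine would show whether the chlorine itself matters. Going by these compounds, it also remains open how a saturated ring such as cyclohexyl, or a chain ending in an amine, would compare with the 3-chlorophenyl and 3-methoxypropyl groups at this same position.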